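Chloro-to-amino exchange on two related cores

The source may report more compounds than this note shows. Statements on the series, on what has been measured and on what is new or still open speak of the compounds shown alone.

Compound 1 `CC1(C)[C@@H](Cn2cnc3c(Cl)nc(N)nc32)CC[C@@]1(C)CO` and compound 2 `CC1(C)[C@@H](Cn2nnc3c(Cl)nc(N)nc32)CC[C@@]1(C)CO` share the same side chain and differ in their cores; the difference between the two cores is not broken down here. In an ADME assay on L1210/0 cells (Mus musculus) for cytotoxicity, with a stated time of 48 h (a higher number here means a weaker inhibitor, a lower number a stronger inhibitor), compound 1 gives 50000 nM. In this assay compound 2 gives 44600 nM, which sits within the scatter of compound 1.

Compound 3 `CC1(C)[C@@H](Cn2cnc3c(N)nc(N)nc32)CC[C@@]1(C)CO` is compound 1 with the change (amino in place of chloro on an aromatic carbon). In this assay compound 3 reports only a limit, > 200000 nM. The step of an at least 4.0-fold higher number from compound 1 to compound 3 (0.60 log units; beyond the scatter) is therefore a lower bound, because the value of compound 3 is the limit described by the limit of > 200000 nM in this assay, at which 1 of the 3 values shown sits, and no number is available for it.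

Compound 4 `CC1(C)[C@@H](Cn2nnc3c(N)nc(N)nc32)CC[C@@]1(C)CO`, not yet measured, is compound 2 with the same change, (amino in place of chloro on an aromatic carbon). The place of the change is the same word for word in both pairs, so this is the same change made on the core of compound 2.

For the measured compounds named here, since compound 2 sits within the scatter of compound 1, and the only precedent for the change is the step from compound 1 to compound 3, compound 4 is expected to show a weakening of the same kind, estimated as a 4.5-fold higher number from compound 2 to compound 4 (0.65 log units; beyond the scatter). The value for compound 4 is estimated at 200000 nM, and it is considered likely that this assay will again report only a limit rather than a number for compound 4.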

Compound 4, half-maximal inhibitory concentration: > 200000 nM
Compound 4: a limit, no number; the forecaster's own chance of this, stated with the estimate: 70%; the middle value sits exactly at the limit.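

In this assay, amino in place of chloro on an aromatic carbon gives an at least 4.4-fold higher number from compound 2 to compound 4 (0.65 log units; beyond the scatter), so the weakening seen on the core of compound 1 also appears on the core of compound 2, and the direction of the change carries over between these two cores: the same change on two cores in this assay, an at least 4.0-fold higher number (0.60 log units; beyond the scatter) from compound 1 to compound 3 and an at least 4.4-fold higher number (0.65 log units; beyond the scatter) from compound 2 to compound 4; the limit leaves it open whether they differ. Compound 4 reports only a limit, > 200000 nM. Each step is therefore a lower bound, and the result does not show that the change has the same size on both cores, nor does it extend beyond these two pairs, since both amino compounds sit at one limit: the limit of > 200000 nM in this assay, at which 2 of the 4 values shown sit.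

The compounds shown leave open how large either step really is, and so whether the core alters the effect of the exchange once numbers rather than limits are available for the amino compounds. They also leave open how other groups on that aromatic carbon would read in this cytotoxicity series, such as a methoxy group, a methylamino group or a thiol, and whether any of these would behave like chloro or like amino on either core.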